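Five-membered to six-membered aryl swap in a weak topoisomerase series

The source may report more compounds than this note shows. Statements on the series, on what has been measured and on what is new or still open speak of the compounds shown alone.

Compound 2 `Oc1ccc(-c2cc(-c3ccoc3)cc(-c3ccccc3O)n2)cc1` gives 3.9% in an assay on isolated protein for inhibition of DNA topoisomerase 1 (Homo sapiens), with a stated time of 30 min, tested at 20 uM; on this read-out lower numbers stand for a weaker effect and higher numbers for a stronger effect at the one concentration tested. Compound 3 `Oc1ccc(-c2cc(-c3ccoc3)cc(-c3cccc(O)c3)n2)cc1` gives 1.3%; the step of a number 2.6 percentage points lower from compound 2 to compound 3 (within the scatter) leaves the two indistinguishable. Compound 1 `Oc1ccc(-c2cc(-c3ccsc3)cc(-c3ccccc3O)n2)cc1` has no number in this assay, its entry being "not determined" (no result reported). Compound 4 `Oc1ccc(-c2cc(-c3cccnc3)cc(-c3ccccc3O)n2)cc1` differs from compound 2 by pyridin-3-yl in place of furan-3-yl on an aromatic carbon. Among the measured compounds shown here, no measured step concerns this position: the only step on record swaps hydroxyphenyl groups and stays within the scatter, so it bears only loosely on compound 4. With both numbers on record low and close together, compound 4 is expected to stay near compound 2, an estimated step of a number 0.1 percentage points higher from compound 2 to compound 4 (within the scatter). Compound 4 is therefore estimated at 4%, with a range from 0% to 15%.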

Compound 4, a percentage reported as inhibition, at one concentration (the size of the read-out at that concentration, not a potency): 0%
The estimate for compound 4 lay 4 percentage points above the measured number; the measured number falls inside the stated range.
By their numbers in this assay, from the lowest: compounds 4, 3 and 2 (each within the scatter of the next).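

With pyridin-3-yl in place of furan-3-yl, the position opposite the ring nitrogen now has a step of its own in this assay, which reads a number 3.9 percentage points lower from compound 2 to compound 4 (within the scatter) and so does not separate the two groups. Going from a five-membered to a six-membered aromatic ring here, with one hetero atom in each, leaves the read-out indistinguishable. No supporting data bear on this result. As far as these compounds go, whether a carboxylic acid or an aminomethyl group at this position would lift the read-out beyond the scatter remains open. Also open, from the compounds shown here alone, is whether any substituent here gives a clear effect on this core.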